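The source may report more compounds than this note shows. Statements on the series, on what has been measured and on what is new or still open speak of the compounds shown alone.

Among the measured compounds shown here, compound 3 `Fc1ccc(-c2cn3ccnc3c(-c3ccc4ncn(C5CCCCC5)c4c3)n2)cc1` stands highest of the three measured members in a physicochemical assay for lipophilicity, using the shake flask method, in phosphate buffer, measured as octanol-water partition, with a stated time of 85 min, at pH 7.4 (on this read-out higher numbers stand for higher lipophilicity and lower numbers for lower lipophilicity), giving 2.01. Compound 2 `O=Cc1ccc(-c2cn3ccnc3c(-c3ccc4ncn(C5CCCCC5)c4c3)n2)cc1` gives 1.5 in this assay, and compound 1 `COc1ccc(-c2cn3ccnc3c(-c3ccc4ncn(C5CCCCC5)c4c3)n2)cc1` gives 1.41. The steps between them are a number 0.09 log units higher from compound 1 to compound 2 (within the scatter), a number 0.60 log units higher from compound 1 to compound 3 (beyond the scatter) and a number 0.51 log units higher from compound 2 to compound 3 (beyond the scatter); all three exchange only the substituent on the six-membered carbon ring while the shared core is kept.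

Compound 4 `c1cn2cc(-c3ccsc3)nc(-c3ccc4ncn(C5CCCCC5)c4c3)c2n1` arises from compound 3 by thiophen-3-yl in place of 4-fluorophenyl on an aromatic carbon. For the measured compounds named here, none of the measured steps covers a replacement of the whole ring; they speak only to the substituent on it, so they bear on compound 4 indirectly, showing that changes at this position have moved this assay by modest amounts and that compound 3 sits at the upper end of the range. A modest downward step a number 0.36 log units lower from compound 3 to compound 4 (beyond the scatter) is therefore expected, though the data do not fix its size. Compound 4 is estimated at 1.65 in this assay, within 1.25 to 2.05.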

Compound 4, partition coefficient: 1.81
For compound 4 the middle estimate is 0.16 log units below the measured one; the range from low to high includes it.
By their numbers in this assay, from the lowest: compounds 1 and 2 (each within the scatter of the next); then compounds 4 and 3 (each within the scatter of the next).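

In this assay, swapping the whole ring at this position for a smaller five-membered ring with a sulfur atom gives a step that stays within the scatter (a number 0.20 log units lower from compound 3 to compound 4 (within the scatter)), so this assay does not separate thiophen-3-yl from 4-fluorophenyl here. The same ring exchange, read against the two other substituted rings, gives steps beyond the scatter (a number 0.31 log units higher from compound 2 to compound 4 (beyond the scatter); a number 0.40 log units higher from compound 1 to compound 4 (beyond the scatter)), which places compound 4 with compound 3 and apart from compound 1 and compound 2. No supporting evidence bears on why the numbers fall this way.

Still open, on these data alone, is how this position responds to a group of another kind, such as an amine, a carboxylic acid or a longer chain. Also open, as far as these compounds go, is whether substituents on the thiophen-3-yl ring would shift the number as those on the six-membered carbon ring did.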